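A few compounds are considered here, and "the series" means these few. Any claim that something is new, unique, unknown or untested is made for them only; others in the source may bear on it.

Measured so far in a functional assay on NCI-H1975 cells (Homo sapiens) for antiproliferative activity, read by MTT assay, with a stated time of 72 h; on this read-out lower numbers stand for stronger inhibition and higher numbers for weaker inhibition:
compound 1 `COc1cc2ncnc(Nc3ccc(C)cc3)c2cc1OCCCCC(=O)Nc1ccc(S(N)(=O)=O)cc1` gives 19300 nM;
compound 2 `CCc1ccc(Nc2ncnc3cc(OC)c(OCCCCC(=O)Nc4ccc(S(N)(=O)=O)cc4)cc23)cc1` gives 10300 nM;
compound 3 `NS(=O)(=O)c1ccc(NC(=S)Nc2ccc3ncnc(Nc4cccc(C(F)(F)F)c4)c3c2)cc1` gives 7590 nM.

Compound 3 gives the lowest of the three numbers, though its gap to compound 2 lies within the scatter; only its gap to compound 1 lies beyond it. Compound 4 `NS(=O)(=O)c1ccc(NC(=S)Nc2ccc3ncnc(Nc4cccc(Cl)c4F)c3c2)cc1` differs from compound 3 by 3-chloro-2-fluorophenyl in place of 3-(trifluoromethyl)phenyl on a nitrogen on an aromatic ring. Among the compounds with values here, the single measured step, a 1.9-fold lower number from compound 1 to compound 2 (0.27 log units; within the scatter), concerns another part of the molecule on a different core, so it says nothing directly about this exchange. Within the data shown here, with no measured step bearing on the change, no shift beyond the scatter is expected in this assay. Compound 4 is therefore estimated at about 6500 nM, within 2500 nM to 18000 nM, which means an expected 1.2-fold lower number from compound 3 to compound 4 (0.07 log units; within the scatter).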

Compound 4, half-maximal inhibitory concentration: 25100 nM
For compound 4 the middle estimate is 3.9-fold (0.59 log units) below the measured one, and the stated range ends below it.
By their numbers in this assay, from the lowest: compounds 3, 2, 1 and 4 (each within the scatter of the next, the first and the last beyond it).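

In this assay, putting 3-chloro-2-fluorophenyl in place of 3-(trifluoromethyl)phenyl on the nitrogen gives a 3.3-fold higher number from compound 3 to compound 4 (0.52 log units; beyond the scatter). Within the data shown here, this is the first step beyond the usual scatter, so the group at this place does affect the read-out. No measurement at hand explains why.

The exchange alters several atoms at once, so the shift cannot be assigned to the chlorine, the fluorine or the loss of trifluoromethyl, and a phenyl carrying chlorine alone would help separate them. From the compounds shown here alone, whether the same exchange has a similar effect on the core of compound 1 also remains open.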